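A few compounds are considered here, and "the series" means these few. Any claim that something is new, unique, unknown or untested is made for them only; others in the source may bear on it.

In a functional assay on HT-29 cells (Homo sapiens) for cytotoxicity, read by MTT assay, with a stated time of 48 h (a higher number here means a weaker inhibitor, a lower number a stronger inhibitor), compound 1 `CS(=O)(=O)c1ccc(Cc2nnc3n2N=C(c2cc(Cl)sc2Cl)CS3)cc1` gives > 100000 nM, which is a limit. Compound 2 `CS(=O)(=O)c1ccc(Cc2nnc3n2N=C(c2ccc(Cl)cc2Cl)CS3)cc1` gives > 100000 nM, also a limit. Compound 3 `Cc1ccc(C2=Nn3c(Cc4ccc(S(C)(=O)=O)cc4)nnc3SC2)cc1` gives > 100000 nM, again a limit and not a number. The series therefore stands at the limit of > 100000 nM in this assay, at which 3 of the 3 values shown sit.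

In compound 4 `CS(=O)(=O)c1ccc(Cc2nnc3n2N=C(c2ccc(O)c(C(N)=O)c2)CS3)cc1`, 3-carbamoyl-4-hydroxyphenyl takes the place of 4-methylphenyl on a carbon with a double bond to nitrogen: 3-carbamoyl-4-hydroxyphenyl in place of 4-methylphenyl on a carbon with a double bond to nitrogen.

The measured steps at this same place are a step that the two limits leave unreadable from compound 1 to compound 2, a step that the two limits leave unreadable from compound 1 to compound 3 and a step that the two limits leave unreadable from compound 2 to compound 3. None of them has a readable size, so they offer no magnitude or direction to carry over. For the measured compounds named here, all three swaps at this place leave the compounds at the limit, and no compound yet shows a number in this assay. No step beyond the scatter is expected, and another limit is the likeliest report. The expected step is a number no higher from compound 3 to compound 4 (the limit leaves the size open). For compound 4 the estimated value is 100000 nM, with an expected range from 30000 nM to 200000 nM.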

Compound 4, half-maximal inhibitory concentration: > 100000 nM
Compound 4 was reported as a limit; the forecaster's own chance of this, stated with the estimate: 70%; the middle value sits exactly at the limit.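

No step from compound 1, compound 2 or compound 3 to compound 4 can be read, since all four sit at the same limit in this assay: the limit of > 100000 nM in this assay, at which 4 of the 4 values shown sit.

The compounds shown leave open whether any group at this place on the shared core gives a readable number in this assay.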